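A few compounds are considered here, and "the series" means these few. Any claim that something is new, unique, unknown or untested is made for them only; others in the source may bear on it.

Measured in an ADME assay on Huh-7 cells (Homo sapiens) for cytotoxicity, read by XTT assay; on this read-out higher numbers stand for lower toxicity in this test and lower numbers for higher toxicity in this test:
- compound 1 `O=C(OC[C@H]1C[C@@H](n2cnc3c(Cl)ncnc32)[C@@H]1CO)c1ccccc1`: 20000 nM
- compound 2 `OC[C@H]1O[C@@H](n2cnc3c(Cl)ncnc32)C[C@@H]1O`: 173000 nM
- compound 3 `OCC(CO)CCn1cnc2c(Cl)ncnc21`: > 200000 nM

Compound 3 gives > 200000 nM, which is a limit of the assay and not a number. Of the two true numbers, compound 2 holds the higher at 173000 nM. The nearest compound is compound 1 at 20000 nM, and that gap lies beyond the usual scatter.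

Compound 4 `CC(C)(C)C(=O)OC[C@H]1O[C@@H](n2cnc3c(Cl)ncnc32)C[C@@H]1O` has not yet been measured in this assay. It differs from compound 2 by (tert-butyl)carbonyl in place of hydrogen on an oxygen on a saturated carbon. Within the data shown here, no measured pair isolates this change, so any expectation is indirect. Among the measured compounds shown here, compound 1 is the only measured compound with a carbonyl group on such an oxygen, although its core differs, and it stands at 20000 nM. On that single comparison, a moderate move towards the lower number is expected. The estimated change is a 2.9-fold lower number from compound 2 to compound 4 (0.46 log units; beyond the scatter), a step expected to lie beyond the scatter. For compound 4 the estimated value is 60000 nM, with an expected range from 20000 nM to 180000 nM.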

Compound 4, half-maximal cytotoxic concentration: 177000 nM
The estimate for compound 4 lay 3.0-fold (0.47 log units) below the measured number; the measured number falls inside the stated range.
By their numbers in this assay, from the lowest: compound 1; then compounds 2 and 4 (each within the scatter of the next). At a limit, above all of these: compound 3.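

In this assay, the step for this change is a 1.0-fold higher number from compound 2 to compound 4 (0.01 log units; within the scatter), so placing (tert-butyl)carbonyl on this oxygen, which turns hydroxymethyl into (((tert-butyl)carbonyl)oxy)methyl, shifts the read-out by no more than the usual scatter. Compound 1 also carries a carbonyl group on such an oxygen, but its core differs as well, so it could not separate the group from the core; this pair holds the core constant and isolates the change at this position. The step needs some caution, because the values of this pair lie not far under the upper limit of the read-out: the limit of > 200000 nM in this assay, at which 1 of the 4 values shown sits.

What the compounds shown leave open is whether a smaller acyl group such as acetyl, or an amine or a carboxylic acid carried on a longer chain at this oxygen, would also stay within the scatter of compound 2. Also open, as far as these compounds go, is whether (tert-butyl)carbonyl would leave the number equally unchanged on the core of compound 1, where the read-out has more room to move in either direction.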